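The source may report more compounds than this note shows. Statements on the series, on what has been measured and on what is new or still open speak of the compounds shown alone.

Of the compounds shown here, three built on one shared core have been tested in an assay on Midbrain with Type-2 angiotensin II receptor (Rattus norvegicus) as the target; on this read-out lower numbers stand for stronger inhibition and higher numbers for weaker inhibition. Compound 3 `CCc1nc2c(C)cc(C)nc2n1Cc1ccc(OC(C(=O)O)c2ccccc2)c(C(C)C)c1` gives 3300 nM, the highest of the three numbers. Compound 1 `CCc1nc2c(C)cc(C)nc2n1Cc1ccc(OC(C(=O)O)c2ccccc2)c(Cl)c1` gives 720 nM, and compound 2 `CCc1cc(Cn2c(CC)nc3c(C)cc(C)nc32)ccc1OC(C(=O)O)c1ccccc1` gives 410 nM. The still unmeasured compound 4 `CCc1nc2c(C)cc(C)nc2n1Cc1ccc(OC(C(=O)O)c2ccccc2)c(Cc2ccccc2)c1` differs from compound 3 by benzyl in place of isopropyl on an aromatic carbon. Two measured steps change the group at that same aromatic carbon: a 4.6-fold higher number from compound 1 to compound 3 (0.66 log units; beyond the scatter) and an 8.0-fold higher number from compound 2 to compound 3 (0.91 log units; beyond the scatter), each weakening as the group grew. Benzyl is larger again than isopropyl, so a further weakening is expected, though its size is uncertain and a step no bigger than the scatter cannot be excluded. Compound 4 is therefore expected to give 6000 nM, within a range from 1500 nM to 25000 nM, which means a 1.8-fold higher number from compound 3 to compound 4 (0.26 log units; within the scatter).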

Compound 4, half-maximal inhibitory concentration: 800 nM
Compound 4: middle estimate off by 7.5-fold (0.88 log units), on the high side; the measured number lies below the stated range.
By their numbers in this assay, from the lowest: compounds 2, 1 and 4 (each within the scatter of the next); then compound 3.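

At this aromatic carbon, a larger group does not always mean weaker binding: benzyl, the largest group here, gives a 4.1-fold lower number from compound 3 to compound 4 (0.62 log units; beyond the scatter). Benzyl cannot be told apart from chloro, a 1.1-fold higher number from compound 1 to compound 4 (0.05 log units; within the scatter), or from ethyl, a 2.0-fold higher number from compound 2 to compound 4 (0.29 log units; within the scatter), so among these four groups only isopropyl stands out, as the weakest. No evidence is available to explain this pattern.

Going by these compounds, it remains open whether the benzyl ring itself matters or any long group would do. A phenyl directly on this carbon, or a longer chain such as butyl, would help separate these possibilities.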